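A few compounds are considered here, and "the series" means these few. Any claim that something is new, unique, unknown or untested is made for them only; others in the source may bear on it.

Two measured compounds share one core and differ only in the aromatic ring attached to one of the two double-bonded chain carbons. Among the compounds with values here, compound 1 `C=CCn1c(=O)/c(=C\c2cccc(Cl)c2)[nH]c(=O)/c1=C\c1ccccc1OC` is the only member with a number: in a functional assay on A549 cells (Homo sapiens) for cytotoxicity, read by CCK-8 assay, with a stated time of 72 h (on this read-out higher numbers stand for weaker inhibition and lower numbers for stronger inhibition), compound 1 gives 5200 nM, a weak result. Compound 2 `C=CCn1c(=O)/c(=C\c2ccc(Cl)c(Cl)c2)[nH]c(=O)/c1=C\c1ccccc1OC` carries a 3,4-dichlorophenyl at that position, and in this assay compound 2 gives "not active" (no number reported), so no single number stands for it and it can only be placed as weaker than anything that did produce a value. Within the data shown here, no step between the two measured compounds is available, since one side of it has no number.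

Compound 3 `C=CCn1c(=O)/c(=C\c2cc(Br)ccc2F)[nH]c(=O)/c1=C\c1ccccc1OC` has not been measured. It differs from compound 2 in one place: 5-bromo-2-fluorophenyl in place of 3,4-dichlorophenyl on a double-bonded chain carbon bound to an aromatic carbon. Both rings are dihalophenyl groups of the same size, and with compound 2 reported inactive and compound 1 itself weak, no move into the potent range is expected; the most likely outcome is weak inhibition or another report of no activity. Compound 3 is estimated at 12000 nM, within a range from 3000 nM to 50000 nM.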

Compound 3, half-maximal inhibitory concentration: "not active" (no number reported)
The entry for compound 3 holds no number, and the estimate cannot be compared.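

Compound 2 and compound 3 are both reported as not active in this assay, so neither has a number and no step can be read between them. The compounds shown leave open which aromatic ring at this place would give a measurable value. No measurement here offers an explanation for this result.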